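Swapping the five-membered ring on compound 2

A few compounds are considered here, and "the series" means these few. Any claim that something is new, unique, unknown or untested is made for them only; others in the source may bear on it.

In a physicochemical assay for solubility, read by LC-MS, in phosphate buffer, with a stated time of 24 h, at pH 7.4 (a lower number here means a less soluble compound, a higher number a more soluble compound), compound 2 (`Cn1nccc1-c1cnc(NCc2c(F)ccc3c2CCO3)c2cn[nH]c(=O)c12`) gives 2000 nM and stands level with compound 1 (`O=C1c2ccccc2CN1c1cnc(NCc2c(F)ccc3c2CCO3)n2cnnc12`) at 4000 nM within the usual scatter. Compound 3 (`CN(C)Cc1ccc(C(=O)Nc2cnc(NCc3c(F)ccc4c3CCO4)n3cnnc23)cc1`) gives 520000 nM in the same measurement, a value beyond the scatter from that of compound 2. Compound 4 (`Cc1ncc(-c2cnc(NCc3c(F)ccc4c3CCO4)c3cn[nH]c(=O)c23)n1C`) carries 1,2-dimethyl-1H-imidazol-5-yl in place of 1-methyl-1H-pyrazol-5-yl on an aromatic carbon of the shared core. Among the measured compounds shown here, no two measured compounds differ in one place only, so no direct precedent guides this step. A small upward move near the edge of the scatter is expected, the estimated change being a 2.0-fold higher number from compound 2 to compound 4 (0.30 log units; within the scatter) in this comparison. In this assay compound 4 is estimated at 4000 nM with an expected range of 1500 nM to 15000 nM for the coming measurement.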

Compound 4, solubility: 15000 nM
Beside the measured number, compound 4's estimate is 3.8-fold (0.57 log units) below it; low and high end bracket the measured number.
By their numbers in this assay, from the lowest: compounds 2 and 1 (each within the scatter of the next); then compound 4; then compound 3.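

In this assay, among the compounds shown here, the change to 1,2-dimethyl-1H-imidazol-5-yl gives a 7.5-fold higher number from compound 2 to compound 4 (0.88 log units; beyond the scatter) and is the first step read at this position. The position therefore responds to an exchange between two five-membered aromatic rings that match in hetero atoms, hydrogen-bond donors, hydrogen-bond acceptors and net charge as counted. No measurement here gives a cause for the step. The compounds shown do not separate the extra methyl from the change of ring itself. They also leave open how an amine or a carboxylic acid on this ring would read.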